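Restoring the substituted benzyl group to compound 3

This account rests on a few compounds, and the source may have more. Where it says the series, first, only, none or still open, it means among the compounds named here.

- compound 1 `COc1ccc(CN(C(=O)CSc2nc3ccccc3s2)c2cc(OC)c(OC)c(OC)c2)cc1[N+](=O)[O-]`: 682 nM
- compound 2 `COc1ccc(CN(C(=O)CSc2nc3ccccc3s2)c2cc(OC)c(OC)c(OC)c2)cc1Br`: 852 nM
- compound 3 `COc1cc(N(Cc2ccc(F)cc2)C(=O)CSc2nc3ccccc3s2)cc(OC)c1OC`: > 80000 nM

In a functional assay on MGC-803 cells (Homo sapiens) for antiproliferative activity, read by MTT assay, with a stated time of 48 h (on this read-out lower numbers stand for stronger inhibition and higher numbers for weaker inhibition), compound 3 gives > 80000 nM. This is a limit of the assay and not a number.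

The next compound to be measured is compound 4 `COc1ccc(CN(C(=O)CSc2nc3ccccc3s2)c2cc(OC)c(OC)c(OC)c2)cc1N`. It differs from compound 3 as follows: 3-amino-4-methoxyphenyl in place of 4-fluorophenyl on a saturated chain carbon bound to an amide-type nitrogen. For the measured compounds named here, two measured steps bear directly on this change, an at least 110-fold higher number from compound 1 to compound 3 (2.06 log units; beyond the scatter) and an at least 93-fold higher number from compound 2 to compound 3 (1.97 log units; beyond the scatter). Both are large, and each ends in 4-fluorophenyl, the group that leaves here. The swap of nitro for bromo gave a 1.2-fold higher number from compound 1 to compound 2 (0.10 log units; within the scatter), so that change made no difference beyond the scatter. Going by the values given here, no compound with 3-amino-4-methoxyphenyl has been measured, which keeps the expected range wide.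

The estimate therefore rests on compound 1 at 682 nM and compound 2 at 852 nM. A large step toward a lower number, meaning stronger inhibition, is expected: an at least 160-fold lower number from compound 3 to compound 4 (2.20 log units; beyond the scatter). The estimated value for compound 4 is 500 nM, with an expected range from 60 nM to 4000 nM.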

Compound 4, half-maximal inhibitory concentration: 84 nM
Compound 4: middle estimate off by 6.0-fold (0.77 log units), on the high side, and the stated range covers the measured number.
By their numbers in this assay, from the lowest: compound 4; then compounds 1 and 2 (each within the scatter of the next). At a limit, above all of these: compound 3.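

In this assay the group on this aromatic carbon proves able to shift the number after all: a 10-fold lower number from compound 2 to compound 4 (1.01 log units; beyond the scatter) and an 8.1-fold lower number from compound 1 to compound 4 (0.91 log units; beyond the scatter) set amino apart from bromo and nitro, two groups that had stayed within the scatter of each other. Compound 4 therefore has the lowest number of the four, with its steps to all the others beyond the scatter. Against the 4-fluorobenzyl compound, an at least 950-fold lower number from compound 3 to compound 4 (2.97 log units; beyond the scatter) gives only a bound, since compound 3 stands at a limit of the assay and not at a number: (the limit of > 80000 nM in this assay, at which 1 of the 4 values shown sits).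

As far as these compounds go, whether a hydroxyl or a dimethylamino group on the same aromatic carbon would follow amino or stay with nitro and bromo remains open. Also open, from the compounds shown here alone, is how much of the large step belongs to the methoxy group and how much to the amino group.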